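From chloro to trifluoromethyl: what to expect of compound 4

The source may hold more compounds than are shown below. What is called first, only, known or untested is meant among the compounds shown, and "the series" means these compounds.

In a physicochemical assay for solubility, read by HPLC, in phosphate buffer, measured as kinetic solubility, at pH 7.4 (a higher number here means a more soluble compound, a lower number a less soluble compound), compound 1 `CCC(=O)c1cc(-c2ccc(S(N)(=O)=O)cc2)n(-c2ccc(Cl)cc2)n1` gives 41900 nM, the second highest of three numbers. Compound 2 `CC(=O)c1cc(-c2ccc(S(N)(=O)=O)cc2)n(-c2ccc(Cl)cc2)n1` gives 86800 nM, and compound 3 `NS(=O)(=O)c1ccc(-c2cc(C(=O)C3CCCC3)nn2-c2ccc(Cl)cc2)cc1` gives 4600 nM. The unmeasured compound 4 `CCC(=O)c1cc(-c2ccc(S(N)(=O)=O)cc2)n(-c2ccc(C(F)(F)F)cc2)n1` keeps the carbonyl side of compound 1 and differs elsewhere: trifluoromethyl in place of chloro on an aromatic carbon. Trifluoromethyl takes the place of chloro on an aromatic carbon, para to a large group. Among the compounds with values here, no measured step touches that place, so the evidence is only indirect. All three measured steps lie on the carbonyl side: a 2.1-fold higher number from compound 1 to compound 2 (0.32 log units; beyond the scatter), a 9.1-fold lower number from compound 1 to compound 3 (0.96 log units; beyond the scatter) and a 19-fold lower number from compound 2 to compound 3 (1.28 log units; beyond the scatter). The first two are modest and the last is large. Among these three compounds, a larger group on the carbonyl goes with a lower number, and none goes against this. Trifluoromethyl is likewise the larger group in its swap, so a modest drop is expected in this assay, though this analogy is weak. The estimated change is a 2.1-fold lower number from compound 1 to compound 4 (0.32 log units; beyond the scatter). Compound 4 is expected at 20000 nM, within an estimated range of 7000 nM to 50000 nM.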

Compound 4, solubility: 7500 nM
For compound 4 the middle estimate is 2.7-fold (0.43 log units) above the measured one; low and high end bracket the measured number.
By their numbers in this assay, from the lowest: compounds 3 and 4 (each within the scatter of the next); then compound 1; then compound 2.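

The chloro position is not a silent spot: in this assay the swap to trifluoromethyl gives a 5.6-fold lower number from compound 1 to compound 4 (0.75 log units; beyond the scatter) and so shows that the number responds to the aromatic side of the molecule as well as to the carbonyl side. The counted change is small, from 1 heavy atom to 4 heavy atoms, with no ring, no hydrogen-bond donor or acceptor and no net charge entering or leaving. Nothing measured here explains why the number moves at this place.

With a single swap at this position, the compounds shown leave open whether a fluoro, a methoxy, a nitrile or an amine there would lower the number or raise it. They also leave open whether trifluoromethyl would have a similar effect on the compounds with an acetyl or cyclopentyl carbonyl side.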